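The source may hold more compounds than are shown below. What is called first, only, known or untested is meant among the compounds shown, and "the series" means these compounds.

Measured compounds:
compound 1 `COc1cc2nc(N3CCN(C(=O)OCc4ccccc4)CC3)nc(N)c2cc1OC` — 63000 nM
compound 2 `COc1ccc(C(=O)N2CCN(c3nc(N)c4cc(OC)c(OC)cc4n3)CC2)cc1OC` — 71000 nM

In a functional assay on PC-3 cells (Homo sapiens) for inhibition (on this read-out higher numbers stand for weaker inhibition and lower numbers for stronger inhibition), compound 1 gives the lowest of the two numbers, and compound 2 stands nearest to it: the step of a 1.1-fold higher number from compound 1 to compound 2 (0.05 log units; within the scatter) does not separate them. Compound 3 `COc1cc2nc(N3CCN(S(=O)(=O)c4ccc(Cl)s4)CC3)nc(N)c2cc1OC` is the compound still to be measured; it differs from compound 1 by (5-chlorothiophen-2-yl)sulfonyl in place of benzyloxycarbonyl on an amine nitrogen in a ring. Among the compounds with values here, only one measured step is available, and it bears on this change only loosely: the step from compound 1 to compound 2 exchanges the group on the carbonyl carbon while keeping a carbonyl on the ring nitrogen, and it stays within the scatter. Within the data shown here, compound 3 removes the carbonyl altogether, and no measured pair shows what a sulfonyl on that ring nitrogen does. The expectation is therefore a step of a 1.1-fold lower number from compound 1 to compound 3 (0.02 log units; within the scatter) beyond the scatter, that is none. For compound 3 the estimate in this assay is 60000 nM, with a range from 15000 nM to 200000 nM.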

Compound 3, half-maximal inhibitory concentration: 25000 nM
Estimate against measurement, compound 3: 2.4-fold (0.38 log units) above, within the range that was stated.
By their numbers in this assay, from the lowest: compound 3; then compounds 1 and 2 (each within the scatter of the next).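

In this assay the replacement of benzyloxycarbonyl by (5-chlorothiophen-2-yl)sulfonyl gives a 2.5-fold lower number from compound 1 to compound 3 (0.40 log units; beyond the scatter) and so moves the number beyond the scatter. Within the data shown here, the earlier exchange on the carbonyl carbon, with a 1.1-fold higher number from compound 1 to compound 2 (0.05 log units; within the scatter) had not done so, which makes this the first sign that the group on this amine nitrogen in a ring can change the read-out, though only by a modest step. No measurement available here accounts for the step.

The change replaces the carbonyl with a sulfonyl and the six-membered aromatic ring with a chlorinated five-membered one in a single move, so the compounds shown do not separate these two parts. As far as these compounds go, whether phenylsulfonyl or 5-chlorothiophene-2-carbonyl on the same nitrogen would give a similar number stays open.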